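This account rests on a few compounds, and the source may have more. Where it says the series, first, only, none or still open, it means among the compounds named here.

In an ADME assay on J774 cells (Mus musculus) for cytotoxicity, read by resazurin assay, with a stated time of 72 h (on this read-out lower numbers stand for higher toxicity in this test and higher numbers for lower toxicity in this test), compounds built on one shared core have so far mostly stayed at the edge of what can be read. Compound 1 `C/C(=N\Nc1nc(CCl)cs1)c1ccc(Cl)c(Cl)c1` gives > 50000 nM, which is a limit of the assay and not a number. Compound 2 `C/C(=N\Nc1nc(-c2ccccn2)cs1)c1ccc(Cl)c(Cl)c1` gives a real number, 10100 nM. Compound 3 `C/C(=N\Nc1nc(-c2ccc(F)cc2)cs1)c1ccc(Cl)c(Cl)c1` gives > 50000 nM, which is again a limit. Compound 3 thus sits at the limit of > 50000 nM in this assay, at which 2 of the 3 values shown sit.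

Compound 4 `C/C(=N\Nc1nc(-c2ccc(-c3ccccc3)cc2)cs1)c1ccc(Cl)c(Cl)c1` differs from compound 3 in one place: phenyl in place of fluoro on an aromatic carbon. This puts phenyl in place of fluoro on an aromatic carbon, para to a large group.

Within the data shown here, no measured step changes a group at this place, so the guidance is indirect. The group on the thiazole-free end of the comparison matters only through three steps: an at least 4.9-fold lower number from compound 1 to compound 2 (0.69 log units; beyond the scatter), an at least 4.9-fold higher number from compound 2 to compound 3 (0.69 log units; beyond the scatter) and a step that the two limits leave unreadable from compound 1 to compound 3. The first two show that a swap of one group on an aromatic carbon can move this assay beyond the scatter, in either direction. The third cannot be sized.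

A modest fall is therefore expected, though another limit is quite possible. The expected step is an at least 1.6-fold lower number from compound 3 to compound 4 (0.22 log units; that floor lies within the scatter). For compound 4 the estimate is 30000 nM, with an expected range from 9000 nM to 80000 nM.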

Compound 4, half-maximal cytotoxic concentration: > 50000 nM
Compound 4 ended at the assay's limit (the forecaster's own chance of this, stated with the estimate: 45%); middle value at least 1.6-fold (0.22 log units) away from the limit.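

Compound 3 and compound 4 both end at a limit of this assay and not at a number, so no step between them can be read: the limit of > 50000 nM in this assay, at which 3 of the 4 values shown sit.

The compounds shown leave open whether phenyl in place of fluoro shifts this read-out at all, in either direction.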